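The source may report more compounds than this note shows. Statements on the series, on what has been measured and on what is new or still open speak of the compounds shown alone.

Measured so far in an in vitro functional assay on cells for agonist activity at Bombesin receptor subtype-3 (Mus musculus), read by luminescence and calcium flux; a lower number here means that less compound is needed, a higher number that more compound is needed for the effect:
compound 1, `O=C(O)c1ccccc1-c1ccc(CCc2ncc(CC3CCCCC3)[nH]2)cc1`: 7.3 nM
compound 2, `N#Cc1ccc(Cc2cnc(CCc3ccc(-c4ccccc4C(=O)O)cc3)[nH]2)cc1`: 723 nM
compound 3, `N#Cc1cccc(Cc2cnc(CCc3ccc(-c4ccccc4C(=O)O)cc3)[nH]2)c1`: 20 nM

Compound 3 holds the second highest of the three numbers in this assay; its nearest neighbour is compound 1, separated by a 2.7-fold higher number from compound 1 to compound 3 (0.44 log units; beyond the scatter), its furthest is compound 2, separated by a 36-fold lower number from compound 2 to compound 3 (1.56 log units; beyond the scatter).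

Compound 4, `O=C(O)c1ccccc1-c1ccc(CCc2ncc(Cc3ccccc3)[nH]2)cc1`, differs from compound 3 by hydrogen in place of cyano on an aromatic carbon. Among the compounds with values here, two measured steps bear on this. a 36-fold lower number from compound 2 to compound 3 (1.56 log units; beyond the scatter) shows that where the cyano sits changes the number greatly, while a 2.7-fold higher number from compound 1 to compound 3 (0.44 log units; beyond the scatter) shows that cyclohexyl and 3-cyanophenyl give numbers not far apart. Within the data shown here, no measured step removes the cyano outright, so the direction is open; a step of modest size at most is expected, a 1.3-fold higher number from compound 3 to compound 4 (0.10 log units; within the scatter). Compound 4 is estimated at 25 nM, within 6 nM to 110 nM.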

Compound 4, half-maximal effective concentration: 11 nM
Beside the measured number, compound 4's estimate is 2.3-fold (0.36 log units) above it; the measured number falls inside the stated range.
By their numbers in this assay, from the lowest: compounds 1, 4 and 3 (each within the scatter of the next, the first and the last beyond it); then compound 2.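

Hydrogen in place of the nitrile on the 3-cyanophenyl group gives a 1.8-fold lower number from compound 3 to compound 4 (0.26 log units; within the scatter), and phenyl in place of cyclohexyl gives a 1.5-fold higher number from compound 1 to compound 4 (0.18 log units; within the scatter), so compound 1, compound 3 and compound 4 do not separate at this position. Against this, a 66-fold lower number from compound 2 to compound 4 (1.82 log units; beyond the scatter) sets only the 4-cyanophenyl group of compound 2 apart from the unsubstituted phenyl. Nothing at hand gives a cause for this.

Open, going by these compounds, is whether the large step belongs to the nitrile alone. A methoxy group or an amine in that place on the phenyl ring could test this.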